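The source may report more compounds than this note shows. Statements on the series, on what has been measured and on what is new or still open speak of the compounds shown alone.

Measured so far in a functional assay on the whole organism (Abdomen, strain Swiss) for inhibition, with Mus musculus as the target, with stated times of 30 min, 10 min and 5 min, at a dose of 40 mg/kg by the oral route; on this read-out higher numbers stand for a stronger effect at the one dose given and lower numbers for a weaker effect:
Compound 1 `Cc1c(C#N)c(-c2ccccc2)nn1CCCN1CCN(c2cccc(Cl)c2)CC1` gives 23% in this assay.
Compound 2 `COc1cccc(N2CCN(CCCn3nc(-c4ccccc4)c(C#N)c3C)CC2)c1` gives 34% in this assay.
Compound 3 `CC(=O)c1cccn1CCCN1CCN(c2cccc(Cl)c2)CC1` gives 54% in this assay.

Compound 1 and compound 2 differ by methoxy in place of chloro on an aromatic carbon, and this made a step of a number 11 percentage points higher from compound 1 to compound 2 (beyond the scatter). Compound 3 rests on another core; the difference between the two cores is not broken down here. Compound 4 `COc1cccc(N2CCN(CCCn3cccc3C(C)=O)CC2)c1` is not yet measured. It arises from compound 3 by methoxy in place of chloro on an aromatic carbon, the same change that took compound 1 to compound 2, at the same place; it occurs twice among these compounds. The expected step is a number 8 percentage points higher from compound 3 to compound 4 (within the scatter), resting on a number 11 percentage points higher from compound 1 to compound 2 (beyond the scatter) and on compound 3 giving 54%, with some allowance for the scatter. Compound 4 is therefore estimated at 62% in this assay, with an expected range from 45% to 78%.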

Compound 4, a percentage reported as inhibition, in the whole organism at one dose (the size of the read-out at that dose, not a potency): 52%
The estimate for compound 4 lay 10 percentage points above the measured number; the range from low to high includes it.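

Going from 3-chlorophenyl to 3-methoxyphenyl on the core of compound 3 gives a step of a number 2 percentage points lower from compound 3 to compound 4 (within the scatter) in this assay. Set beside the earlier step, the two results cannot be told apart: the same change on two cores in this assay, a number 11 percentage points higher (beyond the scatter) from compound 1 to compound 2 and a number 2 percentage points lower (within the scatter) from compound 3 to compound 4, 13 percentage points apart, within the scatter of two such steps. This shows that the change behaved compatibly on both cores, but it does not show that its effect is identical on them, and two pairs at a single dose cannot fix the size of that effect on either core.

The compounds shown leave open how a fluoro group, an amine or a carboxylic acid would read on the aromatic carbon carrying the chloro or methoxy. They also leave open whether a longer chain would alter the result.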